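A few compounds are considered here, and "the series" means these few. Any claim that something is new, unique, unknown or untested is made for them only; others in the source may bear on it.

Compound 1 `CCCCCCCCCCc1cc2cn([C@H]3C[C@H](O)[C@@H](CO)O3)c(=O)nc2o1`: in a functional assay on HEL cells (Homo sapiens) for cytotoxicity, read by microscopy (on this read-out higher numbers stand for lower toxicity in this test and lower numbers for higher toxicity in this test), compound 1 gives > 50000 nM, which is a limit of the test and not a number.
Compound 2 `C=CCCCCCCCCc1cc2cn([C@H]3C[C@H](O)[C@@H](CO)O3)c(=O)nc2o1`: in this assay compound 2 gives > 50000 nM, again a limit of the test rather than a number.

The two measured compounds share one core and differ only in the chain. The step that the two limits leave unreadable from compound 1 to compound 2 cannot be read, since both ends of it sit at the limit of > 50000 nM in this assay, at which 2 of the 2 values shown sit. Within the data shown here, compound 2 therefore stands at the limit of the test, with no number of its own; the only other value shown is likewise a limit.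

Compound 3 `C#CCCCc1cc2cn([C@H]3C[C@H](O)[C@@H](CO)O3)c(=O)nc2o1` differs from compound 2 by ethynyl in place of hept-6-en-1-yl on a saturated chain carbon, three bonds along the chain from an aromatic carbon. Among the measured compounds shown here, no measured step speaks to this change, and the one measured step, from the saturated chain to the terminal alkene, was unreadable. There is thus no ground for expecting a step of any size or direction in this assay, and the expectation is that compound 3 again sits at the limit.

Compound 3 is therefore expected to give about 60000 nM, within 20000 nM to 200000 nM.

The expected step that the limit leaves unreadable from compound 2 to compound 3 is estimated as none beyond the scatter.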

Compound 3, minimum cytotoxic concentration: > 200000 nM
Compound 3: only a limit was reported; the forecaster's own chance of this, stated with the estimate: 85%; middle value at least 3.3-fold (0.52 log units) from the limit.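

Compound 1, compound 2 and compound 3 all sit at limits of the test in this assay, not at numbers, so neither the step from compound 2 to compound 3 nor the step from compound 1 to compound 3 can be read. The compounds shown leave open at what concentration any of them would harm these cells, and whether the change of chain matters for that.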